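The source may hold more compounds than are shown below. What is called first, only, known or untested is meant among the compounds shown, and "the series" means these compounds.

Working notes on the series. Compound 1 `Cc1ccccc1C(=O)Nc1cccc(-c2oc3cc(-c4ccc(F)cc4)ccc3c(=O)c2O)c1` and compound 2 `CCc1ccc(C(=O)Nc2cccc(-c3oc4cc(-c5ccc(F)cc5)ccc4c(=O)c3O)c2)cc1` share one core and differ only in the group attached to the carbonyl carbon of the amide. In a functional assay on HeLa cells (Homo sapiens) for antiproliferative activity, read by CCK-8 assay, with a stated time of 72 h (a lower number here means a stronger inhibitor, a higher number a weaker inhibitor), compound 1 gives 11900 nM, and compound 2 gives 21000 nM. For the measured compounds named here, on the two numbers so far compound 2 stands with compound 1 as its only neighbour, and the single measured step, a 1.8-fold higher number from compound 1 to compound 2 (0.25 log units; within the scatter), lies within the usual spread of repeats, so the two are read as equal. Compound 3 `O=C(Nc1cccc(-c2oc3cc(-c4ccc(F)cc4)ccc3c(=O)c2O)c1)c1cc(F)cc(F)c1` is not yet measured; it keeps the core of compound 2 and carries 3,5-difluorophenyl in place of 4-ethylphenyl on a carbonyl carbon. Going by the values given here, the only step that bears on an exchange at this carbonyl carbon is a 1.8-fold higher number from compound 1 to compound 2 (0.25 log units; within the scatter), which was small, and no other comparison exists, so no step beyond the scatter is expected in this assay. For compound 3 the estimated value in this assay is 16000 nM, with a range from 6000 nM to 45000 nM. The step this estimate implies, a 1.3-fold lower number from compound 2 to compound 3 (0.12 log units; within the scatter), is expected to stay inside the scatter.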

Compound 3, half-maximal inhibitory concentration: 3380 nM
Compound 3: middle estimate off by 4.7-fold (0.68 log units), on the high side; the measured number lies below the stated range.
By their numbers in this assay, from the lowest: compound 3; then compounds 1 and 2 (each within the scatter of the next).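

The aryl group on the carbonyl carbon of the amide does matter in this assay, which the earlier exchange could not show, since its step stayed within the scatter. The exchange to 3,5-difluorophenyl gives a 6.2-fold lower number from compound 2 to compound 3 (0.79 log units; beyond the scatter) and a 3.5-fold lower number from compound 1 to compound 3 (0.55 log units; beyond the scatter) in the same direction, both modest, so among these compounds only compound 3 stands apart, while compounds 1 and 2 remain within the scatter of each other. Nothing measured on these compounds explains why this exchange lowers the number. The compounds shown leave open whether both fluorines are needed or a single fluorine on the phenyl ring would give the same result. They also leave open whether the position tolerates a group other than a substituted phenyl, such as a pyridine ring or a saturated cyclohexyl ring.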